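The compounds below may be only part of what the source reports. "The series", "measured", "known", "first", "only" and "open" are said of these compounds alone.

Measured in a functional assay on SGC-7901 cells (Homo sapiens) for inhibition, read by MTT assay, with a stated time of 24 h; a higher number here means a weaker inhibitor, a lower number a stronger inhibitor:
- compound 1 `CC1(C)[C@H]2CC[C@]1(C)N(Cc1cn(-c3ccc(C#N)cc3)nn1)C(=O)C2`: 500 nM
- compound 2 `CC1(C)[C@H]2CC[C@]1(C)N(Cc1cn(-c3cccc(Cl)c3)nn1)C(=O)C2`: 510 nM
- compound 3 `CC1(C)[C@H]2CC[C@]1(C)N(Cc1cn(-c3ccc(Br)cc3)nn1)C(=O)C2`: 450 nM

These three compounds share one core and differ only in the substituted phenyl group on the aromatic nitrogen. Compound 3 cannot be told apart from the other two, as the steps show: a 1.1-fold lower number from compound 1 to compound 3 (0.05 log units; within the scatter) and a 1.1-fold lower number from compound 2 to compound 3 (0.05 log units; within the scatter). Compound 4 `COc1ccc(-n2cc(CN3C(=O)C[C@@H]4CC[C@@]3(C)C4(C)C)nn2)cc1` keeps the shared core and makes one change to compound 3: methoxy in place of bromo on an aromatic carbon.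

The closest measured step is a 1.1-fold lower number from compound 1 to compound 3 (0.05 log units; within the scatter), which also swaps one group on an aromatic carbon. The step of a 1.0-fold higher number from compound 1 to compound 2 (0.01 log units; within the scatter) is just as small. Among the compounds with values here, all three changes stayed within the scatter, and no compound here goes against that. Within the data shown here, none of the measured compounds carries methoxy, however, so the swap itself is untested. No step beyond the scatter is therefore expected in this assay, though the range is kept wide.

The estimated step is a 1.1-fold higher number from compound 3 to compound 4 (0.03 log units; within the scatter). For compound 4 the expected value is 480 nM, with an estimated range from 240 nM to 950 nM.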

Compound 4, half-maximal inhibitory concentration: 480 nM
Compound 4: middle estimate and measured number agree at the digits printed; the measured number falls inside the stated range.
By their numbers in this assay, from the lowest: compounds 3, 4, 1 and 2 (each within the scatter of the next).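

Methoxy on this aromatic carbon, para to a large group, gives no readable change in this assay from the earlier groups: a 1.1-fold higher number from compound 3 to compound 4 (0.03 log units; within the scatter), a 1.0-fold lower number from compound 1 to compound 4 (0.02 log units; within the scatter) and a 1.1-fold lower number from compound 2 to compound 4 (0.03 log units; within the scatter). The swap from bromo replaces a single bromine with two heavy atoms, one of them an oxygen counted as a hydrogen-bond acceptor, so the flat picture now extends beyond the bromo, cyano and chloro compounds to a group of a different make-up. No measurement shown here bears on what lies behind this flat result.

As far as these compounds go, whether an amine, a carboxylic acid or a longer chain at this position would also stay within the scatter remains open. All four compounds carry the shared core unchanged, so they say nothing about changes to the core itself.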